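Removing two fluorines from a benzamide side chain

The source may hold more compounds than are shown below. What is called first, only, known or untested is meant among the compounds shown, and "the series" means these compounds.

Measured so far:
- compound 1 `O=C(NCCNc1nccc(-c2c(-c3cccc(F)c3)nc3sccn23)n1)c1c(F)cccc1F`: 198000 nM
- compound 2 `O=S(=O)(NCCCNc1nccc(-c2c(-c3cccc(F)c3)nc3sccn23)n1)c1ccc(C(F)(F)F)cc1`: 320000 nM

Of the compounds shown here, two sharing one core have been tested in an ADME assay on L132 cells (Homo sapiens) for cytotoxicity, read by MTT assay; on this read-out lower numbers stand for stronger inhibition and higher numbers for weaker inhibition. In this assay compound 1 gives 198000 nM, and compound 2 gives 320000 nM. Compound 1 has the lower of these two numbers, but the gap to compound 2 lies within the usual scatter of repeated measurements, so the two cannot be told apart on this read-out. Both numbers are high, meaning only weak inhibition of cell viability for either compound.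

Compound 3 `O=C(NCCNc1nccc(-c2c(-c3cccc(F)c3)nc3sccn23)n1)c1ccccc1` has not yet been measured. It differs from compound 1 in one place: phenyl in place of 2,6-difluorophenyl on a carbonyl carbon. The amide linker, the chain and the shared core are unchanged. For the measured compounds named here, no measured pair shows the effect of such a change here, so the only guide is that compound 1 and compound 2, which differ far more widely in their side chains, give numbers within the scatter of each other. On that basis the step from compound 1 to compound 3 in this assay is expected to be small, a 1.1-fold higher number from compound 1 to compound 3 (0.03 log units; within the scatter), with no direction beyond the scatter. Compound 3 is therefore estimated at 210000 nM, in a range from 100000 nM to 450000 nM.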

Compound 3, half-maximal inhibitory concentration: 200000 nM
The estimate for compound 3 lay 1.1-fold (0.02 log units) above the measured number; measured number inside the range.
By their numbers in this assay, from the lowest: compounds 1, 3 and 2 (each within the scatter of the next).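

With phenyl in place of 2,6-difluorophenyl on a carbonyl carbon, this assay gives a step that can be read directly (a 1.0-fold higher number from compound 1 to compound 3 (0.00 log units; within the scatter)), and it shows no difference that this read-out can separate from ordinary repeat variation. For the compounds shown here, this is the first comparison here of two compounds that differ in one place only, so it tests this position directly, whereas the earlier pair differed too widely in their side chains to say anything about any single group. In this cell test, then, the fluorines on this ring can be absent with no detectable difference, although nothing available explains that result.

On these data alone, it remains open whether a larger or differently charged group on this ring, such as a methoxy group, an amine or a carboxylic acid, would give a number clearly different from those of compound 1 and compound 3. As far as these compounds go, it is equally open whether a longer chain in place of the present one, with the benzamide and the shared core kept as they are, would shift the number beyond the usual scatter.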